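A few compounds are considered here, and "the series" means these few. Any claim that something is new, unique, unknown or untested is made for them only; others in the source may bear on it.

Working notes on the series. Two compounds carry numbers in an assay on isolated protein for inhibition of ribosomal protein S6 kinase beta-1 (Homo sapiens), tested at 1 uM (on this read-out higher numbers stand for more inhibition at the one concentration tested (going by the name of the read-out) and lower numbers for less inhibition), so far. Compound 1, `CN(C)C(=O)c1ccc2c(c1)/C(=C(/Nc1ccc(CN3CCCCC3)cc1)c1ccccc1)C(=O)N2`, gives 76% in this assay, the lower of the two numbers. Going by the values given here, compound 2, `CCNC(=O)c1ccc2c(c1)NC(=O)/C2=C(\Nc1ccc(CN(C)C)cc1)c1ccccc1`, gives 101% in this assay, a number that lies beyond the scatter above compound 1; no single-point step connects the two, as they differ in more than one place, so only the two values themselves can be compared.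

The next compound, compound 3, `O=C1Nc2ccccc2/C1=C(/Nc1ccc(CN2CCCCC2)cc1)c1ccccc1`, is unmeasured. It differs from compound 1 in one place: hydrogen in place of dimethylcarbamoyl on an aromatic carbon. Nothing in the two measured compounds isolates the contribution of this group, so the size of the step rests on judgment alone.

The step from compound 1 to compound 3 in this assay is expected to be a modest loss of inhibition, a number 16 percentage points lower from compound 1 to compound 3 (beyond the scatter), not far beyond the usual scatter and possibly within it. Compound 3 is accordingly estimated to give about 60% in this assay, with a plausible range from 25% to 90%.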

Compound 3, a percentage reported as inhibition, at one concentration (the size of the read-out at that concentration, not a potency): 12%
The estimate for compound 3 lay 48 percentage points above the measured number; measured number below the stated range.
By their numbers in this assay, from the lowest: compound 3; then compound 1; then compound 2.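

In this assay, hydrogen in place of dimethylcarbamoyl on this aromatic carbon gives a number 64 percentage points lower from compound 1 to compound 3 (beyond the scatter). Going by these compounds alone, this is the first single-point step, and it shows that this position is not a neutral one: with the rest of compound 1 unchanged, most of the inhibition at the one concentration tested is lost when the dimethylcarbamoyl group leaves. No measurement at hand bears on why the step is this large, so the result stands as an observation about this one pair.

As far as these compounds go, it remains open whether the inhibition depends on dimethylcarbamoyl itself or would also be kept by another group on this aromatic carbon, such as a primary carboxamide, a carboxylic acid or a nitrile. Also open, from the compounds shown here alone, is whether a step of this size would carry over to a compound with the dimethylaminomethyl group of compound 2 on the far aromatic ring, since the present step was read only with the side chain of compound 1.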